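This account rests on a few compounds, and the source may have more. Where it says the series, first, only, none or still open, it means among the compounds named here.

Measured compounds:
Compound 1 `O=C1N/C(=N/c2csc(-c3ccc(Cl)cc3)c2)S/C1=C\c1ccccc1` gives 11200 nM in a functional assay on HCT-116 cells (Homo sapiens) for cytotoxicity, read by MTT assay, with a stated time of 72 h; a lower number here means a stronger inhibitor, a higher number a weaker inhibitor.
Compound 2 `Cc1ccc(/C=C2\S/C(=N\c3csc(-c4ccc(Cl)cc4)c3)NC2=O)cc1` gives 1000 nM in this assay.
Compound 3 `O=C1N/C(=N/c2csc(-c3ccc(Cl)cc3)c2)S/C1=C\c1ccc(O)cc1` gives "not determined" (no result reported) in this assay.

The three measured compounds share one core and differ only in the aromatic group attached to the exocyclic double bond. Among the compounds with values here, the one step that can be counted among them is an 11-fold lower number from compound 1 to compound 2 (1.05 log units; beyond the scatter), a change that lies well beyond the scatter of the measurement. Compound 3 carries a 4-hydroxyphenyl group at that position, and for it no single number was obtained in this assay, so it cannot be placed against compounds 1 and 2.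

Compound 4 `COc1ccc(/C=C2\S/C(=N\c3csc(-c4ccc(Cl)cc4)c3)NC2=O)cc1OC` differs from compound 3 by 3,4-dimethoxyphenyl in place of 4-hydroxyphenyl on a double-bonded chain carbon bound to a double-bonded ring carbon. Within the data shown here, no measured step bears directly on this change; the only step available, from compound 1 to compound 2, shows that a substituent on that aromatic ring can move the number strongly, but it involves a different group. The expectation therefore rests on little, and the width of the range reflects that. Compound 4 is expected to give about 3000 nM in this assay, with a plausible range from 500 nM to 20000 nM.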

Compound 4, half-maximal inhibitory concentration: 1700 nM
Estimate against measurement, compound 4: 1.8-fold (0.25 log units) above; the measured number falls inside the stated range.
By their numbers in this assay, from the lowest: compounds 2 and 4 (each within the scatter of the next); then compound 1.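

In this assay the move to 3,4-dimethoxyphenyl on a double-bonded chain carbon bound to a double-bonded ring carbon gives a 6.6-fold lower number from compound 1 to compound 4 (0.82 log units; beyond the scatter) and so stands beyond the scatter, which makes it the second group, after the 4-methylphenyl of compound 2, to separate clearly from plain phenyl at this position. The comparison of the two substituted rings gives a 1.7-fold higher number from compound 2 to compound 4 (0.23 log units; within the scatter) and lies within the scatter, so this position does not tell 4-methylphenyl and 3,4-dimethoxyphenyl apart, even though they differ in size and in their oxygen atoms. The step from compound 3 to compound 4 cannot be read, as compound 3 has no number, and nothing measured here accounts for any of these results.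

From the compounds shown here alone, whether a single methoxy group, an amine or a carboxylic acid on that aromatic ring would stay with compound 2 and compound 4 or fall back towards compound 1 remains open. All the compounds shown also keep the rest of the shared core unchanged, so how the number responds to a change anywhere else is unknown.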